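The source may report more compounds than this note shows. Statements on the series, on what has been measured and on what is new or still open speak of the compounds shown alone.

In a functional assay on HCC827 cells (Homo sapiens) for inhibition, read by fluorescence and resazurin assay, with a stated time of 72 h (on this read-out lower numbers stand for stronger inhibition of growth and higher numbers for weaker inhibition of growth), two compounds with a shared core have been measured so far. Compound 1 (`N[C@H]1CC[C@H](Nc2nc(Nc3ccc(-c4ccccc4O)cc3)c3ncn(C4CCCC4)c3n2)CC1`) gives 2530 nM, the higher of the two numbers, which makes it the weaker growth inhibitor of the pair. Compound 2 (`COc1ccccc1-c1ccc(Nc2nc(N[C@H]3CC[C@H](N)CC3)nc3c2ncn3C2CCCC2)cn1`) gives 638 nM, and this gap lies beyond the usual scatter. The next compound to be tested is compound 3 (`N[C@H]1CC[C@H](Nc2nc(Nc3ccc(Oc4ncccn4)cc3)c3ncn(C4CCCC4)c3n2)CC1`). It keeps the core of compound 1 but carries (pyrimidin-2-yl)oxy in place of 2-hydroxyphenyl on an aromatic carbon, para to a large group: (pyrimidin-2-yl)oxy in place of 2-hydroxyphenyl on an aromatic carbon. For the measured compounds named here, the two measured compounds differ in more than one place, so no measured step shows directly what this change does in this assay. The expectation therefore rests only on where the two values lie, with compound 1 at 2530 nM and compound 2 lower at 638 nM. A small move toward a lower number is expected, an estimated step of a 1.9-fold lower number from compound 1 to compound 3 (0.29 log units; within the scatter), and it may not clear the scatter. For compound 3 the estimated value is 1300 nM, with an expected range of 400 nM to 3800 nM.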

Compound 3, concentration for 50% growth inhibition: 2720 nM
Estimate against measurement, compound 3: 2.1-fold (0.32 log units) below, within the range that was stated.
By their numbers in this assay, from the lowest: compound 2; then compounds 1 and 3 (each within the scatter of the next).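

In this assay, for the compounds shown here, placing (pyrimidin-2-yl)oxy in place of 2-hydroxyphenyl on an aromatic carbon, para to a large group, gives a 1.1-fold higher number from compound 1 to compound 3 (0.03 log units; within the scatter), the first direct reading of a single change at this position. The exchange is not a small one in what is counted: both groups have 7 heavy atoms, but the hydrogen-bond donor of 2-hydroxyphenyl is gone, the entering group has 3 hydrogen-bond acceptors, and its six-membered aromatic ring has 2 hetero atoms, yet this pair shows no difference in growth inhibition beyond the scatter. No measurement shown here offers an explanation for this result.

From the compounds shown here alone, compound 2 differs from compound 1 in more than one place, so that pair cannot be read as a step, and the contribution of each of its changes remains open. Going by these compounds, it also remains open whether an amine, a carboxylic acid or a longer chain on this same aromatic carbon would give a number that lies beyond the scatter of compound 1 and compound 3.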